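Removing a fluorine from a triazole-linked phenyl ring

This account rests on a few compounds, and the source may have more. Where it says the series, first, only, none or still open, it means among the compounds named here.

Compound 1 `Cc1c(O)ccc2c1[C@H](Cn1cc(-c3ccc(F)cc3)nn1)[C@@]13CC(=O)[C@@](C)(CC[C@@H]21)C3` gives > 20000 nM in a functional assay on MCF7 cells (Homo sapiens) for cytotoxicity, read by MTT assay, with a stated time of 4 days (on this read-out higher numbers stand for weaker inhibition and lower numbers for stronger inhibition), a limit of the assay.
Compound 2 `C=C1C(=O)[C@]23C[C@@]1(O)CC[C@H]2c1ccc(OS(=O)(=O)c2ccc(C)cc2)c(C)c1[C@@H]3Cn1cc(-c2ccc(C)cc2)nn1` gives 320 nM in this assay.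
Compound 3 `Cc1ccc(S(=O)(=O)Oc2ccc3c(c2C)[C@H](Cn2cc(-c4ccc(F)cc4)nn2)[C@@]24CC(=O)[C@@](C)(CC[C@@H]32)C4)cc1` gives > 20000 nM in this assay, again a limit.

Compound 3 sits at the limit of this assay, alongside compound 1 (the limit of > 20000 nM in this assay, at which 2 of the 3 values shown sit); the step that the two limits leave unreadable from compound 1 to compound 3 therefore cannot be read. Compound 4 `Cc1ccc(S(=O)(=O)Oc2ccc3c(c2C)[C@H](Cn2cc(-c4ccccc4)nn2)[C@@]24CC(=O)[C@@](C)(CC[C@@H]32)C4)cc1` differs from compound 3 only in one change: hydrogen in place of fluoro on an aromatic carbon. No measured step among these compounds concerns this change, so nothing here points to a shift beyond the usual scatter in either direction. Because compound 3 gives > 20000 nM, compound 4 is expected to stay near that limit, with an expected step of a number no higher from compound 3 to compound 4 (the limit leaves the size open) and an estimate of 20000 nM, ranging from 5000 nM to 60000 nM.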

Compound 4, half-maximal inhibitory concentration: > 20000 nM
Compound 4 was reported as a limit (the forecaster's own chance of this, stated with the estimate: 70%); the middle value sits exactly at the limit.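

Compound 3 and compound 4 both sit at a limit, so the step between them, from fluoro to hydrogen, cannot be read: the limit of > 20000 nM in this assay, at which 3 of the 4 values shown sit.

The compounds shown leave open whether this swap changes the read-out at all.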